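The compounds below may be only part of what the source reports. "The series", "measured", "known", "first", "only" and "open" are said of these compounds alone.

Three compounds have been measured in a functional assay on A2780 cells (Homo sapiens) for cytotoxicity, read by MTT assay, with a stated time of 24 h; on this read-out lower numbers stand for stronger inhibition and higher numbers for weaker inhibition:

compound 1 `COC(=O)CCNC(=O)Cn1cc(C2=C(c3c[nH]c4ccccc34)C(=O)N(C)C2=O)c2ccccc21`, 44500 nM
compound 2 `COC(=O)[C@@H](CC(C)C)NC(=O)Cn1cc(C2=C(c3c[nH]c4ccccc34)C(=O)N(C)C2=O)c2ccccc21`, 38500 nM
compound 3 `COC(=O)C[C@@H](NC(=O)Cn1cc(C2=C(c3c[nH]c4ccccc34)C(=O)N(C)C2=O)c2ccccc21)C(=O)OC`, 15400 nM

Compound 3 stands lowest of the three, and both of its steps lie beyond the scatter: a 2.9-fold lower number from compound 1 to compound 3 (0.46 log units; beyond the scatter) and a 2.5-fold lower number from compound 2 to compound 3 (0.40 log units; beyond the scatter). Compound 4 `COC(=O)[C@H](NC(=O)Cn1cc(C2=C(c3c[nH]c4ccccc34)C(=O)N(C)C2=O)c2ccccc21)C(C)C` differs from compound 3 by isopropyl in place of (methoxycarbonyl)methyl on a saturated chain carbon bound to an amide-type nitrogen and a carbonyl carbon. The step that bears on this most is a 2.5-fold lower number from compound 2 to compound 3 (0.40 log units; beyond the scatter), in which a methoxycarbonyl took the place of an isopropyl and the number fell; compound 4 undoes a change of that kind, so a modest rise in this assay is expected, back toward compound 2 because 38500 nM belongs to the nearest isopropyl-bearing analogue. Compound 4 is therefore estimated at 35000 nM, within 15000 nM to 80000 nM, an expected step of a 2.3-fold higher number from compound 3 to compound 4 (0.36 log units; beyond the scatter).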

Compound 4, half-maximal inhibitory concentration: 23800 nM
Beside the measured number, compound 4's estimate is 1.5-fold (0.17 log units) above it, and the stated range covers the measured number.
By their numbers in this assay, from the lowest: compounds 3, 4, 2 and 1 (each within the scatter of the next, the first and the last beyond it).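

Among the compounds shown here, replacing (methoxycarbonyl)methyl with isopropyl on this saturated chain carbon gives a 1.5-fold higher number from compound 3 to compound 4 (0.19 log units; within the scatter), so this exchange, unlike the earlier steps to compound 3, stays within the scatter. Isopropyl and isobutyl are not told apart here, with a 1.6-fold lower number from compound 2 to compound 4 (0.21 log units; within the scatter), and the change from the 2-(methoxycarbonyl)ethyl group to the 1-(methoxycarbonyl)-2-methylpropyl group gives a 1.9-fold lower number from compound 1 to compound 4 (0.27 log units; within the scatter), which places compound 4 within the scatter of all three earlier compounds. No evidence is available that bears on these steps. On these data alone, whether a carboxylic acid or an amine on this carbon would move the number beyond the scatter remains open.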